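A few compounds are considered here, and "the series" means these few. Any claim that something is new, unique, unknown or untested is made for them only; others in the source may bear on it.

Within the data shown here, in a physicochemical assay for solubility, using the shake flask method, in simulated intestinal fluid, measured as kinetic solubility, with a stated time of 2 h, at 25 degrees C, at pH 6.5 (a lower number here means a less soluble compound, a higher number a more soluble compound), the series so far comprises compound 1 `Cc1noc(-c2nc(C)c3c(c2N)C(=O)N(Cc2ccccc2Cl)C3=O)n1` and compound 2 `Cc1noc(-c2nc(C)c3c(c2N)C(=O)N(Cc2ccc(Cl)cn2)C3=O)n1`. Compound 1 reads < 5000 nM, which is a limit of the assay and not a number. Compound 2 reads < 5000 nM, which is also a limit. Both compounds therefore stand at the same limit: the limit of < 5000 nM in this assay, at which 2 of the 2 values shown sit. Among the measured compounds shown here, the only measured step, a step that the two limits leave unreadable from compound 1 to compound 2, gives neither a size nor a direction.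

Compound 3 `Cc1noc(-c2nc(C)c3c(c2N)C(=O)N(Cc2ccc(C(N)=O)cc2)C3=O)n1` carries 4-carbamoylphenyl in place of 5-chloropyridin-2-yl on a saturated chain carbon bound to an amide-type nitrogen in a ring. For the measured compounds named here, no measured step of readable size bears on this change. The expected step is a step that the limit leaves unreadable from compound 2 to compound 3, taken as none beyond the scatter, with no direction expected. For compound 3 the estimated value is 3000 nM, with an expected range of 800 nM to 11000 nM.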

Compound 3, solubility: < 5000 nM
Compound 3 was reported as a limit; the forecaster's own chance of this, stated with the estimate: 65%; the middle value does not contradict the limit.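

No step among compound 1, compound 2 and compound 3 can be read in this assay, as each value is a limit of the assay and not a number: the limit of < 5000 nM in this assay, at which 3 of the 3 values shown sit.

The compounds shown leave open whether 2-chlorophenyl, 5-chloropyridin-2-yl and 4-carbamoylphenyl differ at all in this read-out.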